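Bromo to fluoro on the aryl ring of compound 3

The source may hold more compounds than are shown below. What is called first, only, known or untested is meant among the compounds shown, and "the series" means these compounds.

Three compounds of the series have numbers in an assay on isolated protein for inhibition of Polyunsaturated fatty acid 5-lipoxygenase (Homo sapiens); on this read-out higher numbers stand for weaker inhibition and lower numbers for stronger inhibition. Compound 1 `Cc1ccc(N2CCCC(=O)N2)cc1` gives 277000 nM. Compound 2 `COc1ccccc1N1CCCC(=O)N1` gives 204000 nM. Compound 3 `O=C1CCCN(c2cccc(Br)c2)N1` gives 1800 nM, the lowest of the three numbers; its nearest neighbour is compound 2, whose number is higher by a gap beyond the scatter, and compound 1 stands further away still. Going by the values given here, none of these pairs differs in a single place, so no step between measured compounds can be read off.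

Compound 4 `O=C1CCCN(c2cccc(F)c2)N1` is the next member. It differs from compound 3 by fluoro in place of bromo on an aromatic carbon. Among the compounds with values here, no measured pair shows what a halogen swap of this kind does in this assay, so the expectation rests on the value of compound 3 alone. A loss of potency is expected for the step of a 4.4-fold higher number from compound 3 to compound 4 (0.65 log units; beyond the scatter); a result within the scatter is not excluded. The estimate for compound 4 in this assay is 8000 nM, with a range from 2500 nM to 30000 nM.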

Compound 4, half-maximal inhibitory concentration: 5500 nM
The estimate for compound 4 lay 1.5-fold (0.16 log units) above the measured number, and the stated range covers the measured number.
By their numbers in this assay, from the lowest: compound 3; then compound 4; then compounds 2 and 1 (each within the scatter of the next).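

Fluoro in place of bromo on this aromatic carbon brings a 3.1-fold higher number from compound 3 to compound 4 (0.49 log units; beyond the scatter) in this assay and provides the series' first reading of a single change. The position therefore distinguishes between these two halogens, although the step is modest and beyond the scatter, with the lower number staying with bromo. The data available give no explanation for this step.

Whether the trend runs through the halogens remains open, since chloro and iodo on the same aromatic carbon are absent from the compounds shown, and a single step cannot establish an order. Also open, as far as these compounds go, is how groups of another kind at this place, such as nitrile, trifluoromethyl or an amine, would compare with bromo, and whether the same swap elsewhere on the aromatic ring would give a step of similar size.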